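The source may report more compounds than this note shows. Statements on the series, on what has been measured and on what is new or still open speak of the compounds shown alone.

In a functional assay on CCRF-CEM cells (Homo sapiens) (on this read-out lower numbers stand for higher toxicity in this test and higher numbers for lower toxicity in this test), compound 2 `Cc1cn([C@@H]2O[C@H](CO[Si](C)(C)C(C)(C)C)[C@@]3(OS(=O)(=O)C=C3NC(=O)NC(=O)c3ccccc3)[C@H]2O[Si](C)(C)C(C)(C)C)c(=O)n(C)c1=O` gives 2290 nM, the lower of the two numbers available. Among the compounds with values here, the only other measured compound, compound 1 `Cc1cn([C@@H]2O[C@H](CO[Si](C)(C)C(C)(C)C)[C@@]3(OS(=O)(=O)C=C3NCCC(=O)O)[C@H]2O[Si](C)(C)C(C)(C)C)c(=O)n(C)c1=O`, gives 19400 nM. Both carry the same core and differ only in the group on the amine nitrogen.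

The next compound, compound 3 `Cc1cn([C@@H]2O[C@H](CO[Si](C)(C)C(C)(C)C)[C@@]3(OS(=O)(=O)C=C3NCC(=O)C(N)=O)[C@H]2O[Si](C)(C)C(C)(C)C)c(=O)n(C)c1=O`, keeps that core and changes the same group: (carbamoylcarbonyl)methyl in place of benzoylcarbamoyl on an amine nitrogen. In words, (carbamoylcarbonyl)methyl stands in place of benzoylcarbamoyl on an amine nitrogen.

Within the data shown here, one measured step bears on this change: an 8.5-fold lower number from compound 1 to compound 2 (0.93 log units; beyond the scatter), a modest step beyond the scatter, with benzoylcarbamoyl in place of 2-carboxyethyl. Compound 3 gives up the benzoylcarbamoyl group, and its entering chain, like the 2-carboxyethyl of compound 1, has no ring. A partial return towards the number of compound 1 is therefore expected, though this single step is thin support and the new group has not been measured on this core.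

The expected step, towards a higher number in this assay, is a 3.9-fold higher number from compound 2 to compound 3 (0.59 log units; beyond the scatter). For compound 3 the estimated value is 9000 nM, with an expected range of 2800 nM to 29000 nM.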

Compound 3, half-maximal cytotoxic concentration: 9960 nM
Compound 3: the middle estimate sits 1.1-fold (0.04 log units) below what was measured; low and high end bracket the measured number.
By their numbers in this assay, from the lowest: compound 2; then compounds 3 and 1 (each within the scatter of the next).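

In this assay the benzoylcarbamoyl group now has a second ring-free partner on the amine nitrogen, with a 4.3-fold higher number from compound 2 to compound 3 (0.64 log units; beyond the scatter) as the printed change, so compound 2 stands apart from both ring-free compounds by steps beyond the scatter. The two ring-free chains themselves are not separated, since a 1.9-fold lower number from compound 1 to compound 3 (0.29 log units; within the scatter) leaves carbamoylcarbonyl in place of carboxymethyl on a saturated chain carbon bound to an amine nitrogen within the scatter, and the read-out here does not tell the carboxylic acid of compound 1 from the end group of compound 3. Nothing available gives a cause for the gap between compound 2 and the two ring-free compounds.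

The shift from benzoylcarbamoyl to (carbamoylcarbonyl)methyl removes the six-membered aromatic ring and also shortens the group from 11 heavy atoms to 6, so the compounds shown do not say which of the two goes with the lower number of compound 2. A benzyl or phenylacetyl group on the same nitrogen would pull these apart, and a chain ending in an amine or a longer chain ending in a carboxylic acid would show how far the ring-free side extends.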